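Removing the chloro from compound 2: expectation for compound 3

A few compounds are considered here, and "the series" means these few. Any claim that something is new, unique, unknown or untested is made for them only; others in the source may bear on it.

Measured compounds:
- compound 1 `COc1c(C(=O)CCC2CCN(Cc3ccccc3)CC2)cc(Cl)c2[nH]c([Si](C)(C)C)cc12`: "not determined" (no result reported) in an assay for displacement of a labelled ligand from 5-hydroxytryptamine receptor 4 (Homo sapiens), with a stated time of 60 min; a higher number here means a weaker inhibitor, a lower number a stronger inhibitor
- compound 2 `O=C(CCC1CCN(CC2CCCCC2)CC1)c1cc(Cl)c2[nH]ccc2c1`: 37.5 nM

In this assay, among the compounds with values here, compound 2 gives 37.5 nM, the only number available in the set. Within the data shown here, compound 1 is reported only as "not determined" (no result reported), so nothing can be said about how it compares, and no step between two measured compounds exists here.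

Compound 3 `O=C(CCC1CCN(CC2CCCCC2)CC1)c1ccc2[nH]ccc2c1` differs from compound 2 in one place: hydrogen in place of chloro on an aromatic carbon. Everything else, including the cyclohexylmethyl piperidine chain and the ketone linker, is kept.

With no measured pair of this kind in the set, the size of the step cannot be read from the data. The writer expects that the loss of the chloro will weaken binding somewhat, by a margin that goes beyond the usual scatter but stays moderate, so the step from compound 2 to compound 3 is expected to be a 2.9-fold higher number from compound 2 to compound 3 (0.47 log units; beyond the scatter). On that basis compound 3 is estimated at 110 nM, with a range from 35 nM to 350 nM in this assay. The measured value will show whether this expectation holds.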

Compound 3, inhibition constant: 37.5 nM
Estimate against measurement, compound 3: 2.9-fold (0.47 log units) above; low and high end bracket the measured number.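

In this assay, within the data shown here, hydrogen in place of chloro on an aromatic carbon gives no change at the digits printed from compound 2 to compound 3 (within the scatter), the first step in this set that can be read. It shows that, with the cyclohexylmethyl piperidine chain and the ketone linker kept, this position, ortho to a fused ring, can carry either chloro or hydrogen with no difference in the inhibition constant beyond the usual scatter. The chloro of compound 2 is therefore not required for the level of binding seen with this pair, although that finding rests on a single pair. Among these compounds, no step to compound 1 can be read, since compound 1 is entered as "not determined" (no result reported) in this assay. Nothing available here accounts for why the chloro makes no measurable difference.

Going by these compounds, whether this tolerance extends to other groups at the same position, such as fluoro, methoxy or nitrile, remains open. On these data alone, it is also open whether a chloro-to-hydrogen exchange would read the same on a compound with a different chain on the piperidine nitrogen, such as a phenethyl group.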